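A few compounds are considered here, and "the series" means these few. Any claim that something is new, unique, unknown or untested is made for them only; others in the source may bear on it.

Compound 1 `O=c1c2ccccc2ccn1[C@@H]1O[C@H](COP(=O)(O)OP(=O)(O)OP(=O)(O)O)[C@@H](O)[C@H]1O` carries a triphosphate chain on a sugar joined to a bicyclic core. Within the data shown here, in a functional assay for agonist activity at P2Y purinoceptor 2 (Homo sapiens), read by FLIPR (on this read-out lower numbers stand for an effect already at smaller amounts and higher numbers for an effect only at larger amounts of compound), compound 1 gives 31 nM, the lowest of the two numbers known, although compound 2 `O=c1c2c(ccn1[C@@H]1O[C@H](COP(=O)(O)OP(=O)(O)OP(=O)(O)O)[C@@H](O)[C@H]1O)CCCC2`, a close relative, gives 55 nM in this assay, which lies within the scatter of that value. Compound 3 `Cc1cn([C@@H]2O[C@H](COP(=O)(O)OP(=O)(O)OP(=O)(O)O)[C@@H](O)[C@H]2O)c(=O)c2ccccc12` differs from compound 1 by methyl in place of hydrogen on an aromatic carbon. Among the measured compounds shown here, no measured pair shows the effect of such a change, so only a shift no larger than the scatter is expected, estimated as a 1.3-fold higher number from compound 1 to compound 3 (0.11 log units; within the scatter). Compound 3 is therefore expected to give about 40 nM, between 15 nM and 120 nM.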

Compound 3, half-maximal effective concentration: 17500 nM
Compound 3: middle estimate off by 440-fold (2.64 log units), on the low side; the whole stated range lies below it.
By their numbers in this assay, from the lowest: compounds 1 and 2 (each within the scatter of the next); then compound 3.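

Methyl in place of hydrogen on this aromatic carbon, two atoms from the ring nitrogen, brings in this assay a 560-fold higher number from compound 1 to compound 3 (2.75 log units; beyond the scatter). A single added carbon at this one position can therefore change the number far beyond the scatter, which the two earlier compounds could not show. Nothing in the available data explains the size of this step.

As far as these compounds go, whether fluorine, a hydroxyl or an amine on this carbon would bring a similar step stays open. So does whether methyl on another carbon of the same ring would do so.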